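The source may hold more compounds than are shown below. What is called first, only, known or untested is meant among the compounds shown, and "the series" means these compounds.

Working notes on the series.

Compound 1 `COc1c(C#N)c2cc(Cl)c(Cl)cc2n1[C@H]1C[C@H](O)[C@@H](CO)O1` carries a cyano group on the five-membered ring. In a functional assay on KB cells (Homo sapiens) for cytotoxicity, read by spectrophotometry and crystal violet staining (on this read-out higher numbers stand for weaker inhibition and lower numbers for stronger inhibition), compound 1 gives only a limit, > 100000 nM, and no number. Compound 2 `COc1c(C=O)c2cc(Cl)c(Cl)cc2n1[C@H]1C[C@H](O)[C@@H](CO)O1` differs from compound 1 by formyl in place of cyano on an aromatic carbon; in this assay compound 2 gives 20000 nM. The step is an at least 5.0-fold lower number from compound 1 to compound 2 (0.69 log units; beyond the scatter); its true size is open because compound 1 sits at the limit of > 100000 nM in this assay, at which 1 of the 3 values shown sits.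

Compound 3 `N#Cc1c(Cl)n(C2O[C@H](CF)[C@@H](O)[C@H]2O)c2cc(Cl)c(Cl)cc12` is built on a different core; how the two cores differ is not broken down here. In this assay compound 3 gives 50000 nM, a higher number than compound 2 shows. Compound 4 `O=Cc1c(Cl)n(C2O[C@H](CF)[C@@H](O)[C@H]2O)c2cc(Cl)c(Cl)cc12` is not yet measured; it differs from compound 3 by formyl in place of cyano on an aromatic carbon. This is the same kind of change as that from compound 1 to compound 2, though not the same: in compound 3 the carbon that changes is next to the ring atom that bears a chloro group (1 heavy atom) rather than a methoxy group (2 heavy atoms), and two ring bonds from the ring atom that bears a group of 9 heavy atoms rather than 8.

For the measured compounds named here, for compound 4 a lowering of the number of the same kind is expected, a 5.0-fold lower number from compound 3 to compound 4 (0.70 log units; beyond the scatter), resting on the step from compound 1 to compound 2, an at least 5.0-fold lower number from compound 1 to compound 2 (0.69 log units; beyond the scatter), which is the only measured instance of this change. On that basis compound 4 is estimated at 10000 nM, with a likely span from 3000 nM to 40000 nM.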

Compound 4, half-maximal inhibitory concentration: 20000 nM
Compound 4: middle estimate off by 2.0-fold (0.30 log units), on the low side; low and high end bracket the measured number.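

Formyl in place of cyano on an aromatic carbon lowers the number on both cores shown; on the core of compound 3, this assay gives a 2.5-fold lower number from compound 3 to compound 4 (0.40 log units; beyond the scatter), so the direction of the change carries over in the two available pairs. Whether the size of the change also carries over cannot be settled from these pairs: the same change on two cores in this assay, an at least 5.0-fold lower number (0.69 log units; beyond the scatter) from compound 1 to compound 2 and a 2.5-fold lower number (0.40 log units; beyond the scatter) from compound 3 to compound 4; the limit leaves it open whether they differ. Compound 1 gives a limit and not a number, so its step fixes no exact size for comparison, and two pairs establish no general rule for the series: the limit of > 100000 nM in this assay, at which 1 of the 4 values shown sits.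

The two cores differ in more than one place, including a chloro group where the other core has a methoxy group, so the compounds shown do not separate which difference, if any, bears on the size of the step. Also open, on these data alone, is how a carboxylic acid, a primary amide or an aminomethyl group would compare with formyl and cyano on the same aromatic carbon of either core, and whether the lowering seen in this assay would hold on a third core.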